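From cyclopropyl to 1-methylethenyl on a carbonyl carbon

The compounds below may be only part of what the source reports. "The series", "measured", "known", "first", "only" and "open" are said of these compounds alone.

Three compounds of the series have entries in an ADME assay on microsomes from liver (Mus musculus) for metabolic stability, with a stated time of 30 min; on this read-out lower numbers stand for a less stable compound and higher numbers for a more stable compound. For compound 1 (`COC(=O)C(=O)N[C@@H](CO)C(=O)O`) the entry reads "not determined" (no result reported). For compound 2 (`NC(=O)C(=O)N[C@@H](CO)C(=O)O`) the entry reads "not determined" (no result reported). Going by the values given here, compound 3 (`O=C(N[C@@H](CO)C(=O)O)C1CC1`) gives 21%, the only number available so far, so its standing cannot yet be ranked against any other compound in this assay.

Compound 4 (`C=C(C)C(=O)N[C@@H](CO)C(=O)O`) is still to be measured. It has the same atoms as compound 3, joined differently, with 1-methylethenyl in place of cyclopropyl on a carbonyl carbon.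

Among the compounds with values here, no measured pair shows the effect of such a change, so the expectation rests on compound 3 at 21% alone. No step beyond the usual scatter is expected in this assay, in either direction, and confidence in this is limited. The expected change is a number 1 percentage points lower from compound 3 to compound 4 (within the scatter). For compound 4 the estimate is 20%, with an expected range of 5% to 45%.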

Compound 4, percent of the compound remaining: 68%
For compound 4 the middle estimate is 48 percentage points below the measured one; the measured number lies above the stated range.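

Going by these compounds alone, at the carbonyl carbon whose other neighbour is the amide-type nitrogen, 1-methylethenyl in place of cyclopropyl gives a number 47 percentage points higher from compound 3 to compound 4 (beyond the scatter) in this assay, the first step that can be read at this position. The change is large even though the two groups have the same heavy-atom count, neither has hydrogen-bond donors or acceptors, and neither carries a net charge; the difference printed between them is a three-membered ring against an open group with one double bond. Nothing at hand explains the step.

Going by these compounds, whether the higher number goes with the double bond or with the absence of the ring stays open; an isopropyl group at this carbonyl carbon would separate the two. On these data alone, how a longer chain, such as n-butyl, compares here is also open.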